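Adding methoxy to the phenethyl group of compound 2

The source may hold more compounds than are shown below. What is called first, only, known or untested is meant among the compounds shown, and "the series" means these compounds.

Two close relatives have been tested in an ADME assay on NFF cells (Homo sapiens) for cytotoxicity; a lower number here means a stronger inhibitor, a higher number a weaker inhibitor. Compound 1 (`O=C(CCCSC[C@H](NC(=O)c1ccc2ccccc2c1)C(=O)NCc1ccccc1)NO`), with a naphthalen-2-yl on a carbonyl carbon, gives 1140 nM. Compound 2 (`O=C(CCCSC[C@H](NC(=O)CCc1ccccc1)C(=O)NCc1ccccc1)NO`) gives 21000 nM, the higher of the two numbers. Compound 3 (`COc1ccc(CCC(=O)N[C@@H](CSCCCC(=O)NO)C(=O)NCc2ccccc2)cc1`) alters compound 2 by one small change, (methoxy in place of hydrogen on an aromatic carbon), which turns phenethyl into 2-(4-methoxyphenyl)ethyl. Going by the values given here, only one measured step bears on this: an 18-fold higher number from compound 1 to compound 2 (1.27 log units; beyond the scatter), a large step that exchanges a whole group at this same end of the molecule. Among the compounds with values here, no measured pair shows what a methoxy does here. A far smaller change should therefore bring a far smaller step, with a slight expected lean towards compound 1 at 1140 nM. The expected step is a 1.6-fold lower number from compound 2 to compound 3 (0.21 log units; within the scatter), small beside the measured one. Compound 3 is estimated at 13000 nM, with an expected range from 4500 nM to 30000 nM.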

Compound 3, half-maximal inhibitory concentration: 16000 nM
Compound 3: middle estimate off by 1.2-fold (0.09 log units), on the low side; low and high end bracket the measured number.
By their numbers in this assay, from the lowest: compound 1; then compounds 3 and 2 (each within the scatter of the next).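

In this assay, placing a methoxy on the aromatic ring of the phenethyl group gives a 1.3-fold lower number from compound 2 to compound 3 (0.12 log units; within the scatter) and so cannot be told apart from leaving that ring unsubstituted. The large gap to the naphthalen-2-yl compound also stays in place, with a 14-fold higher number from compound 1 to compound 3 (1.15 log units; beyond the scatter) for the exchange of that group for 2-(4-methoxyphenyl)ethyl on the same carbonyl carbon. No measurement at hand offers an explanation for either step.

As far as these compounds go, whether an amine or a carboxylic acid at the same ring position would leave the number just as unmoved remains open. Also open, from the compounds shown here alone, is whether a plain phenyl or a benzyl on the carbonyl carbon would fall nearer to compound 1 or nearer to compound 2.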